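Methyl for methoxy on the aryl ring of compound 2

The source may report more compounds than this note shows. Statements on the series, on what has been measured and on what is new or still open speak of the compounds shown alone.

Measured so far:
compound 1 `COc1ccc(-n2c(Nc3nc(-c4ccc([N+](=O)[O-])cc4)cs3)n[nH]c2=S)cc1`: 100 mg/kg in a functional assay on the whole organism (strain Swiss albino) for inhibition, with Mus musculus as the target, with a stated time of 0.5 h; a higher number here means that more compound is needed for the effect, a lower number that less compound is needed
compound 2 `COc1ccc(-n2c(Nc3nc(-c4ccc(Cl)cc4)cs3)n[nH]c2=S)cc1`: 30 mg/kg in this assay

Compound 2 stands at the lowest number of the two, set apart from compound 1 by a 3.3-fold lower number from compound 1 to compound 2 (0.52 log units; beyond the scatter). Compound 3 `Cc1ccc(-n2c(Nc3nc(-c4ccc(Cl)cc4)cs3)n[nH]c2=S)cc1` differs from compound 2 by methyl in place of methoxy on an aromatic carbon. Among the compounds with values here, the single measured step concerns the other aromatic ring, not this position, so no step beyond the scatter is expected in this assay. Compound 3 is therefore estimated at 30 mg/kg, with a range of 10 mg/kg to 100 mg/kg. This expectation corresponds to no change at the digits printed from compound 2 to compound 3 (within the scatter), with wide uncertainty given the lack of a bearing step.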

Compound 3, minimum effective dose: 300 mg/kg
For compound 3 the middle estimate is 10-fold (1.00 log units) below the measured one, outside the stated range (above it).
By their numbers in this assay, from the lowest: compound 2; then compound 1; then compound 3.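

In this assay the change from 4-methoxyphenyl to 4-methylphenyl gives a 10-fold higher number from compound 2 to compound 3 (1.00 log units; beyond the scatter) and leaves compound 3 as the highest number of the three. The earlier step concerned only the other aromatic ring, whereas this one shows that the group on this ring, para to a large group, also affects the dose required. Nothing at hand bears on the reason for this step.

From the compounds shown here alone, how an ethoxy or a dimethylamino group at this position would compare with methoxy remains open. Also open, going by these compounds, is whether the step would hold with nitro in place of chloro on the other ring.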